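The source may report more compounds than this note shows. Statements on the series, on what has been measured and on what is new or still open speak of the compounds shown alone.

Compound 1 `CC(C)Nc1nc(NCc2ccco2)c2ccccc2n1` and compound 2 `CC(C)Nc1nc(NC2CC2)c2ccccc2n1` share one core, and in an ADME assay on J774.A1 cells (Mus musculus) for inhibition, read by MTT assay, with a stated time of 72 h (a lower number here means that less compound is needed, a higher number that more compound is needed for the effect), compound 1 gives 17000 nM while compound 2 gives 31000 nM. The step of a 1.8-fold lower number from compound 2 to compound 1 (0.26 log units; within the scatter) comes from the change ((furan-2-yl)methyl in place of cyclopropyl on a nitrogen on an aromatic ring). Compound 3 `CC(C)Nc1nc(NC2CC2)nc2ccccc12` carries the same two substituents on another core; the difference between the two cores is not broken down here. For compound 3 this assay reports only a limit, > 40000 nM. Compound 4 `CC(C)Nc1nc(NCc2ccco2)nc2ccccc12` is not yet measured; it differs from compound 3 by (furan-2-yl)methyl in place of cyclopropyl on a nitrogen on an aromatic ring, the same change as that between compound 2 and compound 1. That earlier step stayed within the scatter, so compound 4 is expected to move by a number no higher from compound 3 to compound 4 (the limit leaves the size open). Because compound 3 already sits at the limit of > 40000 nM in this assay, at which 1 of the 3 values shown sits, the assay may again report only a limit for compound 4. Compound 4 is estimated at 40000 nM in this assay, between 15000 nM and 90000 nM.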

Compound 4, half-maximal effective concentration: 8300 nM
For compound 4 the middle estimate is 4.8-fold (0.68 log units) above the measured one; measured number outside the range, below it.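

In this assay, putting (furan-2-yl)methyl in place of cyclopropyl on a nitrogen on an aromatic ring gives an at least 4.8-fold lower number from compound 3 to compound 4 (0.68 log units; beyond the scatter), though compound 3 is known only as a limit of the assay. Set beside the earlier step, the change reads as follows: the same change on two cores in this assay, a 1.8-fold lower number (0.26 log units; within the scatter) from compound 2 to compound 1 and an at least 4.8-fold lower number (0.68 log units; beyond the scatter) from compound 3 to compound 4; the limit leaves it open whether they differ The two pairs show that the change can be carried to the second core without raising the number, but they do not show whether the size of the step depends on the core.

The compounds shown leave open how a longer chain or a benzyl group on that nitrogen would read in this assay. They also leave open whether a carboxylic acid on such a group would fit the same account.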